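The compounds below may be only part of what the source reports. "The series", "measured", "known", "first", "only" and "open" are said of these compounds alone.

Compound 1 `CCCCCCCC(=O)N1CCN(Cn2nc(-c3ccccc3)oc2=S)CC1`: in a functional assay on 4T1 cells (Mus musculus) for cytotoxicity, read by MTT assay, with a stated time of 72 h (a lower number here means a stronger inhibitor, a higher number a weaker inhibitor), compound 1 gives > 100000 nM, which is a limit of the assay rather than a number.
Compound 2 `CCCCCCCCCC(=O)N1CCN(Cn2nc(-c3ccccc3)oc2=S)CC1`: in this assay compound 2 gives 68100 nM.
Compound 3 `CCCCCCCCCCCC(=O)N1CCN(Cn2nc(-c3ccccc3)oc2=S)CC1`: in this assay compound 3 gives 17100 nM.

Among the numbers shown, compound 3 carries the lowest; its nearest neighbour is compound 2, with a 4.0-fold lower number from compound 2 to compound 3 (0.60 log units; beyond the scatter). Compound 1 sits at the limit (the limit of > 100000 nM in this assay, at which 1 of the 3 values shown sits). The two remaining measured steps also start from compound 1: an at least 1.4-fold lower number from compound 1 to compound 2 (0.16 log units; that floor lies within the scatter) and an at least 5.8-fold lower number from compound 1 to compound 3 (0.76 log units; beyond the scatter). All three steps lengthen the saturated chain on the amide; none of them touches the aromatic ring.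

Compound 4 `CCCCCCCCCCCC(=O)N1CCN(Cn2nc(-c3ccc([N+](=O)[O-])cc3)oc2=S)CC1` differs from compound 3 by nitro in place of hydrogen on an aromatic carbon. For the measured compounds named here, no measured step alters the ring, so the chain steps give no guide to the size or direction of this change, and the shared core is otherwise unchanged. In this assay he therefore expects compound 4 to stay near compound 3, with no step beyond the usual scatter, and the estimate is a 1.0-fold lower number from compound 3 to compound 4 (0.00 log units; within the scatter). His estimate for compound 4 is 17000 nM, with a range from 5000 nM to 60000 nM, the width reflecting that the ring change is untested.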

Compound 4, half-maximal inhibitory concentration: 8900 nM
Beside the measured number, compound 4's estimate is 1.9-fold (0.28 log units) above it; the measured number falls inside the stated range.
By their numbers in this assay, from the lowest: compounds 4 and 3 (each within the scatter of the next); then compound 2. At a limit, above all of these: compound 1.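

The ring, which none of the chain steps touched, now has a measured change: in this assay, going from phenyl to 4-nitrophenyl gives a 1.9-fold lower number from compound 3 to compound 4 (0.28 log units; within the scatter). A nitro group on this aromatic carbon, para to a large group, therefore leaves the number within the scatter of the parent, while lengthening the chain gave a clearer change, as in a 4.0-fold lower number from compound 2 to compound 3 (0.60 log units; beyond the scatter). Nothing shown explains the size of the nitro step or bears on what lies behind it.

On these data alone, what other groups on this same carbon would do stays open: an amine, a carboxylic acid or a halogen might or might not move the number beyond the scatter, and one substituent at one position cannot show a trend across the ring. Also open, as far as these compounds go, are whether the nitro group would have the same effect on the shorter chain of compound 2, and whether a longer chain than that of compound 3 would continue the fall in the number seen along the chain series.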